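The source may hold more compounds than are shown below. What is called first, only, known or untested is meant among the compounds shown, and "the series" means these compounds.

In an assay on isolated protein for binding affinity to Gonadotropin-releasing hormone receptor (Homo sapiens) (a higher number here means a weaker inhibitor, a lower number a stronger inhibitor), compound 1 `Cc1cc2c(cc1Cc1ccc(C(=O)NCC3CCCCC3)o1)C(C)(C)CCC2(C)C` gives 180 nM. Going by the values given here, compound 2 `Cc1cc2c(cc1Cc1ccc(C(=O)NC[C@H]3CC[C@H](C(=O)O)CC3)o1)C(C)(C)CCC2(C)C`, which carries a carboxy group on a saturated ring carbon, gives 250 nM in this assay, the highest of the three numbers measured so far. Compound 1 sits within the scatter of it, while compound 3 `Cc1cc2c(cc1Cc1ccc(C(=O)NCC3CCC(CNCc4cc(O)nc(O)n4)CC3)o1)C(C)(C)CCC2(C)C`, which gives 24 nM, lies well apart. Compound 4 `Cc1cc2c(cc1Cc1ccc(C(=O)NCC3CCN(C(=N)N)CC3)o1)C(C)(C)CCC2(C)C` has not yet been measured. It differs from compound 2 in one place: a group of 9 heavy atoms (6 carbon, 3 nitrogen; one six-membered non-aromatic ring with 1 hetero atom) in place of a group of 9 heavy atoms (7 carbon, 2 oxygen; one six-membered non-aromatic ring of carbon only), on a saturated chain carbon bound to an amide-type nitrogen. Among the compounds with values here, two measured steps bear on this change. The step of a 1.4-fold higher number from compound 1 to compound 2 (0.14 log units; within the scatter) shows that adding the carboxy group made no real difference. The step of a 7.5-fold lower number from compound 1 to compound 3 (0.88 log units; beyond the scatter) shows that a larger, nitrogen-containing group with hydrogen-bond donors on a saturated ring carbon gave a modestly stronger binder. The group entering compound 4 likewise brings nitrogen and hydrogen-bond donors. On that basis a modest move toward a lower number is expected for compound 4, a 3.6-fold lower number from compound 2 to compound 4 (0.55 log units; beyond the scatter). Compound 4 is therefore estimated at 70 nM in this assay, with a likely range from 15 nM to 300 nM.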

Compound 4, inhibition constant: 220 nM
Compound 4: the middle estimate sits 3.1-fold (0.50 log units) below what was measured, and the stated range covers the measured number.
By their numbers in this assay, from the lowest: compound 3; then compounds 1, 4 and 2 (each within the scatter of the next).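

In this assay, replacing the 4-carboxycyclohexyl group on a saturated chain carbon bound to an amide-type nitrogen gives a 1.1-fold lower number from compound 2 to compound 4 (0.06 log units; within the scatter), and setting the same new group against the plain carbon ring gives a 1.2-fold higher number from compound 1 to compound 4 (0.09 log units; within the scatter). At this place, then, three different six-membered rings read alike, and a ring with nitrogen and hydrogen-bond donors does not by itself bring the lower number that compound 3 shows at 24 nM. No measurement shown here explains why these rings read alike.

From the compounds shown here alone, it remains open whether the lower number of compound 3 goes with its dihydroxypyrimidine or with its secondary amine. A plain aminomethyl group on the same carbon ring, without the pyrimidine, would help separate the two.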